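Inverting a Chain Stereocentre in a Lactone Series

The source may hold more compounds than are shown below. What is called first, only, known or untested is meant among the compounds shown, and "the series" means these compounds.

Of the compounds shown here, three have been tested in a functional assay on A2780 ADR cells (Homo sapiens) for cytotoxicity, read by MTT assay, with a stated time of 24 h; on this read-out lower numbers stand for stronger inhibition and higher numbers for weaker inhibition. Compound 1 `CCCCC[C@H](CCC[C@@H]1CC=CC(=O)O1)OC` gives 20500 nM, and compound 3 `CCCCC[C@@H](CCC[C@@H]1CC=CC(=O)O1)OC` gives 11500 nM. These two share all atoms and bonds and differ only in configuration as drawn (the fact that compounds 1 and 3 differ only in the configuration as drawn), and the step between them is a 1.8-fold lower number from compound 1 to compound 3 (0.25 log units; within the scatter). Compound 2 `CCCCC[C@H](C[C@H](O)C[C@H]1CC=CC(=O)O1)OC` gives 57500 nM, the highest of the three numbers, standing beyond the scatter above both compound 1 and compound 3.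

Compound 4 `CCCCC[C@@H](C[C@H](O)C[C@H]1CC=CC(=O)O1)OC` is the untested partner of compound 2: the two compounds have the same atoms and bonds and differ only in configuration as drawn: 1 of 3 stereo elements differ; a stereocentre at a saturated chain carbon is drawn R in compound 2 and S in compound 4. Among the measured compounds shown here, the only measured step that bears on this change is the same kind of inversion at a saturated chain carbon, a 1.8-fold lower number from compound 1 to compound 3 (0.25 log units; within the scatter), which stayed within the scatter. On that basis little movement beyond the scatter is expected in this assay for compound 4, perhaps a small shift to a lower number, and the estimated step is a 1.4-fold lower number from compound 2 to compound 4 (0.16 log units; within the scatter). Compound 4 is therefore estimated at 40000 nM, with a range from 15000 nM to 100000 nM.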

Compound 4, half-maximal inhibitory concentration: 48000 nM
Beside the measured number, compound 4's estimate is 1.2-fold (0.08 log units) below it; the measured number falls inside the stated range.
By their numbers in this assay, from the lowest: compounds 3 and 1 (each within the scatter of the next); then compounds 4 and 2 (each within the scatter of the next).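

Inverting the saturated chain carbon now has a second reading in this assay, in compounds that also carry a hydroxyl group on the chain and a third stereo element: a 1.2-fold lower number from compound 2 to compound 4 (0.08 log units; within the scatter). Alongside the earlier 1.8-fold lower number from compound 1 to compound 3 (0.25 log units; within the scatter), this means the inversion stays within the scatter in both pairs, not only in the simpler one. Across these two pairs, then, the configuration drawn at this carbon does not separate the compounds on this read-out.

The compounds shown leave open whether this configuration would matter with a different group in place of the methoxy group, such as an amine, or with a longer chain in place of the pentyl end. They also leave open how inverting the other stereocentres would read, since only this one carbon is varied here.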